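Carboxy to 1H-Tetrazol-5-yl on Two Related Cores

The compounds below may be only part of what the source reports. "The series", "measured", "known", "first", "only" and "open" are said of these compounds alone.

Compound 1 `CC(CCCC(=O)O)c1cccc(OCc2ccc3ccccc3n2)c1`: 500 nM
Compound 2 `CCCC(CCC(=O)O)Cc1ccc(OCc2ccc3ccccc3n2)cc1`: 30 nM
Compound 3 `CCCC(CCc1nnn[nH]1)Cc1ccc(OCc2ccc3ccccc3n2)cc1`: 32 nM

In a functional assay (lung) for inhibition, with Cavia porcellus as the target (on this read-out lower numbers stand for stronger inhibition and higher numbers for weaker inhibition), compound 1 gives 500 nM, the highest of the three numbers, while compound 2 gives 30 nM and compound 3 gives 32 nM. The difference between the core of compound 1 and the core of compound 2 is not broken down here. From compound 2 to compound 3 the change is 1H-tetrazol-5-yl in place of carboxy on a saturated chain carbon, four bonds along the chain from an aromatic carbon, and it produced a 1.1-fold higher number from compound 2 to compound 3 (0.03 log units; within the scatter). Compound 4 `CC(CCCc1nnn[nH]1)c1cccc(OCc2ccc3ccccc3n2)c1` arises from compound 1 by the same change, (1H-tetrazol-5-yl in place of carboxy on a saturated chain carbon, four bonds along the chain from an aromatic carbon), at the same place on the chain. For compound 4 a step of a 1.1-fold higher number from compound 1 to compound 4 (0.04 log units; within the scatter) is expected, because a 1.1-fold higher number from compound 2 to compound 3 (0.03 log units; within the scatter) lay within the scatter on the other core. Compound 4 is therefore estimated at 550 nM, with a likely range from 250 nM to 1200 nM.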

Compound 4, half-maximal inhibitory concentration: 250 nM
Compound 4: the middle estimate sits 2.2-fold (0.34 log units) above what was measured; the range from low to high includes it.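

In this assay the change from carboxy to 1H-tetrazol-5-yl on the core of compound 1 gave a 2.0-fold lower number from compound 1 to compound 4 (0.30 log units; within the scatter) and thus no step beyond the scatter. Set beside the same change on the other core, the two steps do not differ beyond what repeated measurements allow: the same change on two cores in this assay, a 1.1-fold higher number (0.03 log units; within the scatter) from compound 2 to compound 3 and a 2.0-fold lower number (0.30 log units; within the scatter) from compound 1 to compound 4, 2.1-fold (0.33 log units) apart, within the scatter of two such steps. Among these compounds, this shows that the change carried across these two cores without a step beyond the scatter, but with only two pairs in one assay it does not show that it would carry to any further core.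

The compounds shown leave open whether the same would hold for a longer chain bearing the 1H-tetrazol-5-yl. They also leave open how a sulfonamide or an amide in place of carboxy would compare on either core.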